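Fluoro replaces 2-hydroxyethyl on the double bond

This account rests on a few compounds, and the source may have more. Where it says the series, first, only, none or still open, it means among the compounds named here.

In an ADME assay for pharmacokinetics, read by LC-MS, in phosphate buffer, with a stated time of 120 min, at pH 7.4, tested at 1 uM, in the presence of a further agent that is not named here (a higher number here means that the compound lasts longer, a lower number that the compound disappears faster), compound 3 `C=C(CCO)C(=O)Nc1ccccc1` gives > 8.53 h, which is a limit and not a number. Compound 2 `C/C=C/C(=O)Nc1ccccc1` gives > 8.53 h, also a limit. Compound 1 `C=C(Cl)C(=O)Nc1ccccc1`, by contrast, gives 0.05 h.

Compound 4 `C=C(F)C(=O)Nc1ccccc1` carries this change: fluoro in place of 2-hydroxyethyl on a double-bonded chain carbon bound to a carbonyl carbon. Fluoro enters on the double-bonded chain carbon bound to a carbonyl carbon, where compound 1 carries chloro. Two large measured steps bear on this: an at least 170-fold higher number from compound 1 to compound 3 (2.23 log units; beyond the scatter), and an at least 170-fold higher number from compound 1 to compound 2 (2.23 log units; beyond the scatter). Fluoro is not chloro, so only part of the first step is expected to reverse. A shorter half-life is therefore expected, an estimated at least 5.6-fold lower number from compound 3 to compound 4 (0.75 log units; beyond the scatter). The estimated half-life of compound 4 is 1.5 h, with an expected range from 0.2 h to 8 h.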

Compound 4, half-life: > 8.53 h
Compound 4: a limit, no number (the forecaster's own chance of this, stated with the estimate: 15%); middle value at least 5.6-fold (0.75 log units) from the limit.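

Compound 1's fast disappearance in this assay does not extend to every halogen on the double-bonded chain carbon bound to a carbonyl carbon: fluoro in place of chloro gives an at least 170-fold higher number from compound 1 to compound 4 (2.23 log units; beyond the scatter). Among the compounds shown, chloro is thus the only group at this place tied to fast loss. The steps linking compound 4 to compound 2 and compound 3 cannot be read, because all three values are the same limit: the limit of > 8.53 h in this assay, at which 3 of the 4 values shown sit.

From the compounds shown here alone, how long compound 4 actually lasts remains open. So does how a bromo group or an amine would behave at this place.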